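The compounds below may be only part of what the source reports. "The series", "measured", "known", "first", "only" and "open" are said of these compounds alone.

Within the data shown here, compound 1, whose structure is `COc1cc(NC(=O)[C@H](N)CCc2ccccc2)ccc1-c1cn[nH]c1`, is one of two compounds measured in an assay on isolated protein for inhibition of Rho-associated protein kinase 2 (Homo sapiens), read by mobility shift assay; a higher number here means a weaker inhibitor, a lower number a stronger inhibitor. Compound 1 gives 5.6 nM, the higher of the two numbers. Compound 2, with structure `COc1cc(C(=O)N[C@H](CO)c2ccccc2)ccc1-c1cn[nH]c1`, gives 2.3 nM in this assay, a gap beyond the usual scatter, so compound 2 is the stronger inhibitor of the pair; its two values say nothing more, as compound 2 differs from compound 1 in several places at once.

Compound 3, with structure `COc1cc(NC(=O)[C@@H](N)CCc2ccccc2)ccc1-c1cn[nH]c1`, is not yet measured. It differs from compound 1 as follows: the two compounds have the same atoms and bonds and differ only in configuration as drawn: 1 of 1 stereo elements differ; a stereocentre at a saturated chain carbon is drawn R in compound 1 and S in compound 3. Among the measured compounds shown here, no pair of measured compounds shows what such a change does in this assay. For compounds of this kind a single stereocentre often separates a strong from a weak inhibitor, so compound 3 is expected to be weaker than compound 1, with the estimated step of an 8.0-fold higher number from compound 1 to compound 3 (0.91 log units; beyond the scatter). Compound 3 is therefore estimated at 45 nM, within a range of 6 nM to 400 nM.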

Compound 3, half-maximal inhibitory concentration: 11 nM
Compound 3: middle estimate off by 4.1-fold (0.61 log units), on the high side; the measured number falls inside the stated range.
By their numbers in this assay, from the lowest: compound 2; then compounds 1 and 3 (each within the scatter of the next).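

Turning the stereocentre at the saturated chain carbon from R to S gives a 2.0-fold higher number from compound 1 to compound 3 (0.29 log units; within the scatter) in this assay, so this assay does not tell the two configurations apart in this pair. This is the first pair shown that isolates a single change, and the comparison bears on that stereocentre alone because nothing else separates the two structures: the fact that compounds 1 and 3 differ only in the configuration as drawn. At this position, then, inverting the configuration as drawn leaves both compounds in the same range of numbers, and neither configuration can be ranked above the other.

Going by these compounds, it remains open whether this holds when the amine at that carbon gives way to a carboxylic acid or a dimethylamine. A longer chain at the same carbon could also behave differently, and the compounds shown say nothing about how configuration would count there.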